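The compounds below may be only part of what the source reports. "The series", "measured", "known", "first", "only" and "open" are said of these compounds alone.

Working notes on the series in a functional assay on MDA-MB-468 cells (Homo sapiens) for antiproliferative activity, read by MTT assay; on this read-out higher numbers stand for weaker inhibition and lower numbers for stronger inhibition. Compound 3 `COc1ccc(Nc2ccnc(Nc3ccc(NS(=O)(=O)c4ccc(OC)cc4)cc3)n2)cc1` gives 14800 nM in this assay, the lowest of the two numbers shown. Compound 1 `Cc1cc(Nc2ccc(F)cc2)nc(Nc2ccc(NS(=O)(=O)c3ccc(C(F)(F)F)cc3)cc2)n1` gives 32300 nM in this assay, a gap beyond the scatter. For compound 2 `COc1ccc(Nc2cc(C)nc(Nc3ccc(NS(=O)(=O)c4c(Cl)cc(C)cc4OC)cc3)n2)cc1` this assay reports only a limit, > 50000 nM; that is the limit of > 50000 nM in this assay, at which 1 of the 3 values shown sits. Compound 4 `COc1ccc(Nc2ccnc(Nc3ccc(NS(=O)(=O)c4ccc(C)cc4)cc3)n2)cc1` differs from compound 3 in one place: methyl in place of methoxy on an aromatic carbon. Going by the values given here, no measured pair shows this change, so the expected step of a 1.0-fold higher number from compound 3 to compound 4 (0.01 log units; within the scatter) is one within the scatter, with no clear direction. Compound 4 is therefore expected to give 15000 nM in this assay, within a range from 5000 nM to 45000 nM.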

Compound 4, half-maximal inhibitory concentration: > 50000 nM
Compound 4: only a limit was reported (the forecaster's own chance of this, stated with the estimate: 20%); middle value at least 3.3-fold (0.52 log units) from the limit.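

The change from (4-methoxyphenyl)sulfonyl to (4-methylphenyl)sulfonyl gives the only one-place step shown in this assay, an at least 3.3-fold higher number from compound 3 to compound 4 (0.52 log units; beyond the scatter), so this position is not indifferent to methyl in place of methoxy. Compound 4 carries only a limit, so the step has a floor and no upper end. Compound 4 joins compound 2 at that limit: the limit of > 50000 nM in this assay, at which 2 of the 4 values shown sit.

Going by these compounds, how an ethoxy group, an amine or a carboxylic acid would read at this position stays open. Also open, on these data alone, is whether the same change gives a similar step on the methyl-bearing core of compound 1.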